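Furan-2-yl swap on the trifluoroethyl ester of compound 3

This account rests on a few compounds, and the source may have more. Where it says the series, first, only, none or still open, it means among the compounds named here.

In an assay on HEK293 cells for displacement of a labelled ligand from adenosine receptor A2b (Homo sapiens), read by radioligand binding, with a stated time of 30 min (on this read-out lower numbers stand for stronger inhibition and higher numbers for weaker inhibition), compound 3 `CC1=C(C(=O)OCC(F)(F)F)C(c2ccoc2)NC(=O)N1` gives 588 nM, the higher of the two single numbers measured, while compound 2 `CC1=C(C(=O)OC(C)C(F)(F)F)C(c2ccoc2)NC(=O)N1` gives 234 nM; the step of a 2.5-fold higher number from compound 2 to compound 3 (0.40 log units; beyond the scatter) is modest. Compound 1 `CC1=C(C(=O)OC(C)C(F)(F)F)C(c2ccco2)NC(=O)N1` gives 61.5 nM; 303 nM (2 entries), and the spread in the several entries of compound 1 in this assay, 61.5 nM; 303 nM (2 entries) makes its comparison with compound 2 uncertain. Compound 4 `CC1=C(C(=O)OCC(F)(F)F)C(c2ccco2)NC(=O)N1` differs from compound 3 by furan-2-yl in place of furan-3-yl on a saturated ring carbon. Within the data shown here, no measured step covers this change directly; the only guide is compound 1 against compound 2, whose numbers overlap within the scatter. Compound 4 is therefore expected to show a step of a 1.7-fold lower number from compound 3 to compound 4 (0.23 log units; within the scatter) of modest size toward a lower number at most. Compound 4 is estimated at 350 nM, with a range from 120 nM to 1000 nM.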

Compound 4, inhibition constant: 157 nM
The estimate for compound 4 lay 2.2-fold (0.35 log units) above the measured number; measured number inside the range.
By their numbers in this assay, from the lowest: compounds 4 and 2 (each within the scatter of the next); then compound 3.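

With the trifluoroethyl ester held fixed, furan-2-yl in place of furan-3-yl on the saturated ring carbon gives a 3.7-fold lower number from compound 3 to compound 4 (0.57 log units; beyond the scatter) in this assay. The way the furan is attached therefore matters at this position, even though the two groups have the same atoms. Compound 1 and compound 2 carry the same change but could not settle it: the several entries of compound 1 in this assay, 61.5 nM; 303 nM (2 entries)

Going by these compounds, whether this step holds with other esters remains open. So does how a thiophen-2-yl or phenyl group, or an amine on the furan, would read at this ring carbon.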